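Swapping the chlorophenyl arm of compound 3 for a furan

The source may hold more compounds than are shown below. What is called first, only, known or untested is meant among the compounds shown, and "the series" means these compounds.

The three measured compounds share one core and differ at two arms. Compound 1 `O=C(O)Cc1sc(NCc2ccccc2)nc1-c1ccc(Cl)cc1` carries a benzylamino arm and, in an in vitro functional assay on HEK285-7 cells for antagonist activity at prostaglandin D2 receptor 2 (Homo sapiens), read by BRET and beta-arrestin recruitment (a higher number here means a weaker inhibitor, a lower number a stronger inhibitor), compound 1 gives 2300 nM. Compound 2 `O=C(O)Cc1sc(C(c2ccccc2)c2ccc(F)cc2)nc1-c1ccc(Cl)cc1` replaces that arm with a diarylmethyl group bearing a single fluorine; in this assay compound 2 gives 36 nM. Compound 3 `O=C(O)Cc1sc(C(c2ccc(F)cc2)c2ccc(F)cc2)nc1-c1ccc(Cl)cc1` adds a second fluorine to that group, and in this assay compound 3 gives 180 nM. Among the compounds with values here, the only single-point step among them is a 5.0-fold higher number from compound 2 to compound 3 (0.70 log units; beyond the scatter). Within these three numbers, compound 3 stands second highest, closer to compound 2 than to compound 1.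

Compound 4 `O=C(O)Cc1sc(C(c2ccc(F)cc2)c2ccc(F)cc2)nc1-c1ccoc1` is the unmeasured analogue. It differs from compound 3 as follows: furan-3-yl in place of 4-chlorophenyl on an aromatic carbon. Within the data shown here, none of the measured steps touches this position, since the only measured step concerns the fluorine on the diarylmethyl group, so there is no direct guide to the size or direction of the change. Given that the diarylmethyl-bearing compounds 2 and 3 sit far from compound 1, the diarylmethyl arm appears to carry most of the potency, and the change at the other arm is expected to be moderate. Compound 4 is therefore estimated at 500 nM, with a range of 150 nM to 2000 nM, a step of a 2.8-fold higher number from compound 3 to compound 4 (0.44 log units; beyond the scatter), most likely toward a weaker inhibitor.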

Compound 4, half-maximal inhibitory concentration: 130 nM
Compound 4: the middle estimate sits 3.8-fold (0.59 log units) above what was measured, and the stated range ends above it.
By their numbers in this assay, from the lowest: compound 2; then compounds 4 and 3 (each within the scatter of the next); then compound 1.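

Within the data shown here, at the aromatic carbon next to the ring nitrogen, the earlier compounds gave no reading, and here this assay shows a 1.4-fold lower number from compound 3 to compound 4 (0.14 log units; within the scatter) when furan-3-yl replaces 4-chlorophenyl. With the bis(4-fluorophenyl)methyl arm held fixed, this position therefore accepts a five-membered aromatic ring with 1 hetero atom in place of a six-membered aromatic ring of carbon only, and the loss of the chlorine and the arrival of a hydrogen-bond acceptor leave the two compounds indistinguishable in this assay. Nothing available explains why the two groups read alike.

The compounds shown leave open whether furan-3-yl would behave the same way beside the singly fluorinated arm of compound 2, where the number is lower than for compound 3, or beside the benzylamino arm of compound 1. They also leave open how far this tolerance extends at this position, for example to furan-2-yl, thiophene, pyridine, an unsubstituted phenyl or a ring carrying an amine.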